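This account rests on a few compounds, and the source may have more. Where it says the series, first, only, none or still open, it means among the compounds named here.

The measured compounds in a functional assay on the whole organism (strain Swiss) with Mus musculus as the target, in the maximal electroshock model, with a stated time of 0.5 h, at a dose of 300 mg/kg by the intraperitoneal route; on this read-out lower numbers stand for a weaker effect and higher numbers for a stronger effect at the one dose given:
compound 1 `COc1cccc(N2CCN(C(=O)C(C)N3C(=O)CCC3=O)CC2)c1` gives 50%
compound 2 `CC(C(=O)N1CCN(c2ccc(Cl)cc2)CC1)N1C(=O)CCC1=O` gives 100%
compound 3 `CC(C(=O)N1CCN(c2ccc(C(F)(F)F)cc2)CC1)N1C(=O)CCC1=O` gives 25%

Compound 3 stands lowest of the three; compound 1 is nearest to it and compound 2 furthest, both beyond the scatter. Compound 4 `CC(C(=O)N1CCN(c2ccc(F)cc2)CC1)N1C(=O)CCC1=O` has not yet been measured; it differs from compound 3 by fluoro in place of trifluoromethyl on an aromatic carbon. Within the data shown here, two measured steps bear on this change: a number 50 percentage points higher from compound 1 to compound 2 (beyond the scatter) and a number 75 percentage points lower from compound 2 to compound 3 (beyond the scatter). Among the measured compounds shown here, the second concerns the very group now being removed, so its reversal points upward, though no measured step connects fluoro to either chloro or trifluoromethyl, and the size remains uncertain. For compound 4 a step of a number 35 percentage points higher from compound 3 to compound 4 (beyond the scatter) is expected. Compound 4 is therefore estimated at 60% in this assay, with a range from 25% to 100%.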

Compound 4, a percentage reported as activity, at one dose (the size of the read-out at that dose, not a potency): 50%
For compound 4 the middle estimate is 10 percentage points above the measured one; the measured number falls inside the stated range.
By their numbers in this assay, from the lowest: compound 3; then compounds 1 and 4 (each within the scatter of the next); then compound 2.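

With fluoro on this aromatic carbon, this assay gives a number 25 percentage points higher from compound 3 to compound 4 (beyond the scatter), yet also a number 50 percentage points lower from compound 2 to compound 4 (beyond the scatter). Among the three groups compared here, only chloro reaches the top value, so removing trifluoromethyl does not by itself restore that level. Exchanging the 3-methoxyphenyl for the 4-fluorophenyl gives no change at the digits printed from compound 1 to compound 4 (within the scatter). Nothing available explains these differences. As far as these compounds go, whether bromo or methyl at this place would match chloro remains open.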